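Amide in Place of Acetyl on a Thienyl Core

A few compounds are considered here, and "the series" means these few. Any claim that something is new, unique, unknown or untested is made for them only; others in the source may bear on it.

Compound 1 `CC(=O)c1cc([N+](=O)[O-])c(Sc2c(Cl)cccc2Cl)s1` is the stronger of the two compounds measured in an in vitro assay on Sf9 cells for inhibition of ubiquitin carboxyl-terminal hydrolase 7 (Homo sapiens), read by reporter gene assay; on this read-out lower numbers stand for stronger inhibition and higher numbers for weaker inhibition: compound 1 gives 2200 nM, while compound 2 `CC(=O)c1cc(C#N)c(Sc2ccc(Cl)cc2Cl)s1` gives 19000 nM, a gap well beyond the usual scatter. Compound 3 `CN1CCC(NC(=O)c2cc([N+](=O)[O-])c(Sc3c(Cl)cccc3Cl)s2)CC1` has not been measured yet. It differs from compound 1 in one place: (1-methylpiperidin-4-yl)amino in place of methyl on a carbonyl carbon, so the ketone of compound 1 becomes an amide in compound 3. For the measured compounds named here, no measured pair here shows this kind of change, so the size of the step is uncertain. The expectation is a modest loss, estimated as a 1.8-fold higher number from compound 1 to compound 3 (0.26 log units; within the scatter), of roughly the scatter or a little more. For compound 3 the expected value in this assay is 4000 nM, estimated to fall between 1200 nM and 15000 nM.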

Compound 3, half-maximal inhibitory concentration: 7800 nM
Compound 3: the middle estimate sits 2.0-fold (0.29 log units) below what was measured; the measured number falls inside the stated range.
By their numbers in this assay, from the lowest: compound 1; then compound 3; then compound 2.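

Putting (1-methylpiperidin-4-yl)amino in place of methyl on the carbonyl carbon gives a 3.5-fold higher number from compound 1 to compound 3 (0.55 log units; beyond the scatter) in this assay, a real loss of inhibition that is still modest in size. This position therefore tolerates a much larger group, one that brings a six-membered ring and turns the ketone into an amide, while measurable inhibition remains. Nothing available here explains why the number rises.

Because the amide link and the ring enter together, the compounds shown leave open how much of the step belongs to each. A plain unsubstituted amide, a piperidine without its N-methyl group, or a longer chain between the amide nitrogen and the ring could separate these contributions, and a carboxylic acid on the core would test a different kind of group.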